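A few compounds are considered here, and "the series" means these few. Any claim that something is new, unique, unknown or untested is made for them only; others in the source may bear on it.

Compound 1 `CC(C)(C)[C@]1(c2ccccc2)OCC[C@H](CCNCc2ccccc2)O1`: in an assay on brain for displacement of a labelled ligand from Sigma non-opioid intracellular receptor 1 (Cavia porcellus) (a higher number here means a weaker inhibitor, a lower number a stronger inhibitor), compound 1 gives 253 nM.
Compound 2 `CC(C)(C)[C@]1(c2ccccc2)OCC[C@H](CCN)O1`: compound 2 gives > 10000 nM, a limit of this assay, not a number.

Compound 2 thus stands at the limit described by the limit of > 10000 nM in this assay, at which 1 of the 2 values shown sits. Among the compounds with values here, the one measured step, an at least 39-fold higher number from compound 1 to compound 2 (1.59 log units; beyond the scatter), ends at that limit and concerns the benzyl on the amine nitrogen. Compound 3 `CC(C)(C)[C@@]1(c2ccccc2)OCC[C@@H](CCN)O1` differs from compound 2 in the two compounds have the same atoms and bonds and differ only in configuration as drawn: 2 of 2 stereo elements differ (all stereocentres are inverted: mirror images); a stereocentre at a saturated ring carbon is drawn S in compound 2 and R in compound 3; a stereocentre at a saturated ring carbon is drawn S in compound 2 and R in compound 3. Within the data shown here, no measured step involves an inversion of configuration, so nothing here sizes this change. Compound 3 is therefore expected near the same limit, estimated at 12000 nM (range 2500 nM to 60000 nM), a step that the limit leaves unreadable from compound 2 to compound 3, most likely reported only as a limit again.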

Compound 3, inhibition constant: > 10000 nM
Compound 3 ended at the assay's limit; the forecaster's own chance of this, stated with the estimate: 65%; the middle value does not contradict the limit.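

No step can be read from compound 2 to compound 3, because both stop at: the limit of > 10000 nM in this assay, at which 2 of the 3 values shown sit.

The compounds shown leave open whether inverting both stereocentres changes the value when the amine nitrogen carries benzyl, as in compound 1.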